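A few compounds are considered here, and "the series" means these few. Any claim that something is new, unique, unknown or untested is made for them only; others in the source may bear on it.

Working notes on the series. In a functional assay on PANC-1 cells (Homo sapiens) for cytotoxicity, read by WST assay, with a stated time of 24 h (a lower number here means a stronger inhibitor, a higher number a weaker inhibitor), compound 1 `O=C(CCCCCCCCc1ccccc1)N1CCCCC1` gives > 100000 nM, which is a limit of the assay and not a number. Compound 2 `O=C(CCCCCCCCc1ccc(O)cc1)N1CCCCC1` gives > 100000 nM, which is likewise only a limit. Among the measured compounds shown here, compound 2 therefore has no numerical potency to build on, and the one other value beside it is also a limit: the limit of > 100000 nM in this assay, at which 2 of the 2 values shown sit.

The next structure is compound 3 `O=C(CCCCCCCCc1cccc(F)c1)N1CCCCC1`, and the change from compound 2 is 3-fluorophenyl in place of 4-hydroxyphenyl on a saturated chain carbon, eight bonds along the chain from a carbonyl carbon. For the measured compounds named here, one measured step bears on this change: a step that the two limits leave unreadable from compound 1 to compound 2. That step also concerns a group on the aromatic ring, but it has no readable size, so it gives neither a magnitude nor a direction for compound 3. Neither compound 1 nor compound 2 yields a number, so no shift beyond the scatter is expected in this assay.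

The expected outcome is a number no higher from compound 2 to compound 3 (the limit leaves the size open), an estimated step with no clear direction. Compound 3 is expected to lie near 100000 nM, with an estimated range of 50000 nM to 200000 nM, and will most likely be reported as a limit again.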

Compound 3, half-maximal inhibitory concentration: > 100000 nM
Compound 3 ended at the assay's limit; the forecaster's own chance of this, stated with the estimate: 80%; the middle value lies on the limit itself.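

No step can be read among compound 1, compound 2 and compound 3, because each value is only a limit and none is a number: the limit of > 100000 nM in this assay, at which 3 of the 3 values shown sit.

The compounds shown leave open whether any change to the shared core would give a numerical potency in this assay, and how large the effect of any ring substituent would be.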